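Hydroxymethyl on the chain carbon of compound 2

The compounds below may be only part of what the source reports. "The series", "measured", "known", "first", "only" and "open" are said of these compounds alone.

In a functional assay on HeLa cells (Homo sapiens) for antiproliferative activity, read by MTT assay, with a stated time of 48 h (a higher number here means a weaker inhibitor, a lower number a stronger inhibitor), compound 2 `O=C(CNC(=O)c1cc2ccccc2cn1)OCc1ccccc1` gives 195 nM and stands level with compound 1 `NC(=O)C[C@H](NC(=O)c1cc2ccccc2cn1)C(=O)OCc1ccccc1` at 216 nM within the scatter. Compound 3 `O=C(C[C@@H]1CCCN1C(=O)c1cc2ccccc2cn1)OCc1ccccc1` reads lower at 87.7 nM beyond the scatter of compound 2.

Compound 4 `O=C(N[C@@H](CO)C(=O)OCc1ccccc1)c1cc2ccccc2cn1` has hydroxymethyl in place of hydrogen on a saturated chain carbon bound to an amide-type nitrogen and a carbonyl carbon and is otherwise the same as compound 2. Among the compounds with values here, the only measured step at that carbon is a 1.1-fold lower number from compound 1 to compound 2 (0.04 log units; within the scatter) with hydrogen in place of carbamoylmethyl, and it stays within the scatter. Hydroxymethyl itself has not been measured in this series, so this evidence is indirect. With that single step of a 1.1-fold lower number from compound 1 to compound 2 (0.04 log units; within the scatter) as the guide, no change beyond the scatter is expected in this assay in either direction. The expected change is a 1.0-fold higher number from compound 2 to compound 4 (0.01 log units; within the scatter) and is estimated to stay within the scatter. For compound 4 the estimated value is 200 nM with an expected range from 95 nM to 420 nM in this series.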

Compound 4, half-maximal inhibitory concentration: 135 nM
The estimate for compound 4 lay 1.5-fold (0.17 log units) above the measured number; low and high end bracket the measured number.
By their numbers in this assay, from the lowest: compounds 3, 4, 2 and 1 (each within the scatter of the next, the first and the last beyond it).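

In this assay, hydroxymethyl on a saturated chain carbon bound to an amide-type nitrogen and a carbonyl carbon gives a 1.4-fold lower number from compound 2 to compound 4 (0.16 log units; within the scatter), so this position now has a second substituent that stays level with hydrogen. Among compounds 1, 2 and 4, none of the steps at this carbon leaves the scatter, and no compound among these three goes against that. Hydroxy in place of carbamoyl on a saturated chain carbon, two bonds along the chain from an amide-type nitrogen and a carbonyl carbon, gives a 1.6-fold lower number from compound 1 to compound 4 (0.20 log units; within the scatter), which shows that the two substituted compounds also stay level.

On these data alone, whether an amine, a carboxylic acid or a longer chain at this carbon would shift the number beyond the scatter remains open. Nothing at hand gives a reason for these steps.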